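The compounds below may be only part of what the source reports. "The series", "measured", "known", "first", "only" and "open" are said of these compounds alone.

Compound 1 `[O-][n+]1nc(NCOC2CCCCC2)[n+]([O-])c2ccccc21` gives 10800 nM in a functional assay on K562 cells (Homo sapiens) for cytotoxicity, read by MTT assay, with a stated time of 72 h; on this read-out higher numbers stand for weaker inhibition and lower numbers for stronger inhibition.
Compound 2 `[O-][n+]1nc(NCOCc2ccccc2)[n+]([O-])c2ccccc21` gives 16100 nM in this assay.
Compound 3 `[O-][n+]1nc(NCOCc2ccc(Cl)cc2)[n+]([O-])c2ccccc21` gives 3260 nM in this assay.

Compound 3 holds the lowest number of the three, its steps to compound 1 and to compound 2 both lying beyond the scatter. Compound 4 `CC(C)CCOCNc1n[n+]([O-])c2ccccc2[n+]1[O-]` differs from it in one place: isobutyl in place of 4-chlorophenyl on a saturated chain carbon bound to an oxygen on a saturated carbon. Within the data shown here, two measured steps bear on this. Swapping a saturated ring for an aromatic one gave a 1.5-fold higher number from compound 1 to compound 2 (0.17 log units; within the scatter), so the loss of the aromatic ring itself is expected to matter little. Adding the chlorine gave a 4.9-fold lower number from compound 2 to compound 3 (0.69 log units; beyond the scatter), and compound 4 gives that chlorine up. The change is therefore expected to undo that gain, so a rise in the number is estimated, a 3.7-fold higher number from compound 3 to compound 4 (0.57 log units; beyond the scatter). Compound 4 is expected to give about 12000 nM, within 4000 nM to 35000 nM.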

Compound 4, half-maximal inhibitory concentration: 13100 nM
The estimate for compound 4 lay 1.1-fold (0.04 log units) below the measured number, and the stated range covers the measured number.
By their numbers in this assay, from the lowest: compound 3; then compounds 1, 4 and 2 (each within the scatter of the next).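

In this assay, the step of a 4.0-fold higher number from compound 3 to compound 4 (0.60 log units; beyond the scatter) shows that at this position, the lower number among these groups goes with 4-chlorophenyl alone. Isobutyl in place of phenyl gives a 1.2-fold lower number from compound 2 to compound 4 (0.09 log units; within the scatter) and isopentyl in place of cyclohexyl gives a 1.2-fold higher number from compound 1 to compound 4 (0.08 log units; within the scatter) so an open chain, a saturated ring and an unsubstituted phenyl are not told apart here. Nothing at hand explains this result. As far as these compounds go, it remains open whether fluoro or methoxy in place of the chloro would match compound 3, and how an amine at the end of the chain would fare.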